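The compounds below may be only part of what the source reports. "The series", "measured", "known", "first", "only" and "open" are said of these compounds alone.

Notes on the series. Compound 1 `CC1=CC[C@H](C(C)C)c2cc(C)c(OC(=O)Nc3ccccc3)cc21` carries an anilino group on its carbonyl carbon, and in a functional assay on SK-LU-1 cells (Homo sapiens) for antiproliferative activity, read by sulforhodamine B assay, with a stated time of 48 h, tested at 50 uM (on this read-out higher numbers stand for more inhibition at the one concentration tested (going by the name of the read-out) and lower numbers for less inhibition), compound 1 gives 100%. Compound 2 `CC1=CC[C@H](C(C)C)c2cc(C)c(OC(=O)c3ccc([N+](=O)[O-])cc3)cc21` gives 47.5%, and compound 3 `CC1=CC[C@H](C(C)C)c2cc(C)c(OC(=O)c3cccc([N+](=O)[O-])c3)cc21` gives 60.4%. The steps of a number 52.5 percentage points lower from compound 1 to compound 2 (beyond the scatter) and a number 39.6 percentage points lower from compound 1 to compound 3 (beyond the scatter) both run downward, while a number 12.9 percentage points higher from compound 2 to compound 3 (beyond the scatter). On the numbers shown, compound 3 stands second of the three, separated from compound 2 and from compound 1 beyond the scatter in each case.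

Compound 4 `COc1ccc(C(=O)Oc2cc3c(cc2C)[C@@H](C(C)C)CC=C3C)cc1` has not yet been measured. Its difference from compound 3: 4-methoxyphenyl in place of 3-nitrophenyl on a carbonyl carbon. For the measured compounds named here, no measured step exchanges a nitrophenyl for a methoxyphenyl, so nothing bears on this change directly. What the measured steps do show is that the two compounds with a nitrophenyl on the carbonyl carbon, compound 2 and compound 3, lie well under compound 1, and that moving the nitro group within that ring shifts the read-out only modestly, a number 12.9 percentage points higher from compound 2 to compound 3 (beyond the scatter). Compound 4 again carries an aryl ring on the carbonyl carbon, so the expected number lies in the region of compound 2 and compound 3 rather than of compound 1. The expected step of a number 10.4 percentage points lower from compound 3 to compound 4 (beyond the scatter) is small relative to the wide uncertainty. The estimate for compound 4 in this assay is 50%, expected to fall between 25% and 80%.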

Compound 4, a percentage reported as inhibition, at one concentration (the size of the read-out at that concentration, not a potency): 18.6%
Compound 4: middle estimate off by 31.4 percentage points, on the high side; measured number below the stated range.
By their numbers in this assay, from the lowest: compound 4; then compound 2; then compound 3; then compound 1.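

Compound 4 shows that the substituent on the aryl ring at this carbonyl carbon can move the read-out well beyond what the nitro shift alone suggested: in this assay, the exchange of 3-nitrophenyl for 4-methoxyphenyl gives a number 41.8 percentage points lower from compound 3 to compound 4 (beyond the scatter), and the exchange of methoxy for nitro on an aromatic carbon gives a number 28.9 percentage points lower from compound 2 to compound 4 (beyond the scatter). Compound 4 now sits beyond the scatter under each of the other three, and the gap to the anilino compound widens to a number 81.4 percentage points lower from compound 1 to compound 4 (beyond the scatter), so all three compounds with an aryl ring on the carbonyl carbon lie under compound 1, with none going against this among those shown. No accompanying measurement speaks to why methoxy and nitro part so far on this ring.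

Still open, going by these compounds, is whether the fall belongs to the methoxy group or to the loss of the nitro group, which an unsubstituted phenyl ring or a phenyl ring bearing an amine would help to separate. Also open, on these data alone, is how a 3-methoxyphenyl group would compare with the 4-methoxyphenyl group at this carbonyl carbon.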